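The source may hold more compounds than are shown below. What is called first, only, known or untested is meant among the compounds shown, and "the series" means these compounds.

Compound 1 `CN1CCN(c2nc(Oc3ccc(C#N)cc3)nc(-c3ccc(N4C(=O)CSC4c4ccc(Br)cc4)cc3)n2)CC1`: in an ADME assay on Vero cells (Chlorocebus sabaeus) for cytotoxicity, read by MTT assay, with a stated time of 72 h (on this read-out lower numbers stand for stronger inhibition and higher numbers for weaker inhibition), compound 1 gives > 62.5 ug/mL, which is a limit of the assay and not a number.
Compound 2 `CN1CCN(c2nc(Oc3ccc(C#N)cc3)nc(-c3ccc(N4C(=O)CSC4c4ccc(O)cc4)cc3)n2)CC1`: in this assay compound 2 gives > 62.5 ug/mL, again a limit of the assay.
Compound 3 `CN1CCN(c2nc(Oc3ccc(C#N)cn3)nc(-c3ccc(N4C(=O)CSC4c4ccc(Br)cc4)cc3)n2)CC1`: in this assay compound 3 gives "not determined" (no result reported), so no result exists for it.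

Compound 3 therefore stands nowhere on the numbers: it has no value in this assay, and the two values that do exist are both limits, as the limit of > 62.5 ug/mL in this assay, at which 2 of the 3 values shown sit, records. Within the data shown here, the only step between measured compounds, a step that the two limits leave unreadable from compound 1 to compound 2, is left unreadable by those two limits.

Compound 4 `COc1ccc(C2SCC(=O)N2c2ccc(-c3nc(Oc4ccc(C#N)cn4)nc(N4CCN(C)CC4)n3)cc2)cc1` differs from compound 3 by methoxy in place of bromo on an aromatic carbon. Among the measured compounds shown here, no measured step bears readably on this change; what the record offers is the limit of > 62.5 ug/mL in this assay, at which 2 of the 3 values shown sit, which places both measured compounds at the same limit. No step beyond the scatter can be expected in this assay, in either direction. Compound 4 is accordingly estimated at 70 ug/mL, within a range of 30 ug/mL to 150 ug/mL, and it is expected that the assay will most likely again report only a limit.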

Compound 4, half-maximal inhibitory concentration: > 62.5 ug/mL
Compound 4: no number, only a limit; the forecaster's own chance of this, stated with the estimate: 80%; the middle value does not contradict the limit.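

In this assay compound 4 gives > 62.5 ug/mL, which is a limit of the assay and not a number. Compound 3 has no reported result, so no step from compound 3 to compound 4 can be read: the limit of > 62.5 ug/mL in this assay, at which 3 of the 4 values shown sit.

The compounds shown leave open what the change from 4-bromophenyl to 4-methoxyphenyl does in this assay.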